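The source may report more compounds than this note shows. Statements on the series, on what has been measured and on what is new or still open speak of the compounds shown alone.

The measured compounds:

Compound 1 `Nc1cc(N)c2nc(-c3ccccc3)c(NCc3ccc(Cl)c(Cl)c3)nc2c1`: in a functional assay on RXF 393 cells (Homo sapiens) for inhibition, read by sulforhodamine B assay, with a stated time of 48 h (on this read-out higher numbers stand for lower toxicity in this test and lower numbers for higher toxicity in this test), compound 1 gives < 100000 nM, which is a limit of the assay and not a number.
Compound 2 `COc1cc(CNc2nc3cc(N)cc(N)c3nc2-c2ccccc2)cc(OC)c1OC`: in this assay compound 2 gives < 50200 nM, likewise a limit.
Compound 3 `CCOC(=O)[C@H](CCC(=O)O)NC(=O)c1ccc(CNc2nc3cc(N)cc(N)c3nc2-c2ccccc2)cc1`: in this assay compound 3 gives < 100000 nM, again a limit.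

Compound 1 therefore stands only at a limit, namely at the limit of < 100000 nM in this assay, at which 2 of the 3 values shown sit. The other two values are limits as well, one of them at the limit of < 50200 nM in this assay, at which 1 of the 3 values shown sits, so none of the three compounds can be placed in order against another; the numbers shown say only that each sits at or beyond its limit.

Compound 4 `Nc1cc(N)c2nc(-c3ccccc3)c(NCc3ccc(F)cc3)nc2c1` has not yet been measured. It differs from compound 1 in one place: 4-fluorophenyl in place of 3,4-dichlorophenyl on a saturated chain carbon bound to a nitrogen on an aromatic ring. Going by the values given here, no step between two measured compounds is known, and every value shown is a limit, so the account has nothing that would point to a change in either direction in this assay; the expectation is no step beyond the usual scatter. On that basis the step from compound 1 to compound 4 is estimated at a step that the limit leaves unreadable from compound 1 to compound 4. For compound 4 the expected value in this assay is 80000 nM, in the range 20000 nM to 100000 nM, with a fair chance that only a limit is reported again.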

Compound 4, concentration lethal to 50% of the cells: 60300 nM
Estimate against measurement, compound 4: 1.3-fold (0.12 log units) above; low and high end bracket the measured number.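

No step can be read from compound 1 to compound 4 in this assay, because compound 1 stands only at a limit: the limit of < 100000 nM in this assay, at which 2 of the 4 values shown sit.

The compounds shown leave open whether 4-fluorophenyl in place of 3,4-dichlorophenyl changes the result in this assay at all, and, if it does, in which direction and by how much.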